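The compounds below may be only part of what the source reports. "The series", "measured", "known", "first", "only" and "open" are said of these compounds alone.

In a functional assay on HeLa cells (Homo sapiens) for cytotoxicity, read by MTT assay, with a stated time of 24 h (a lower number here means a stronger inhibitor, a higher number a weaker inhibitor), three compounds with the shared core have been measured. Compound 1 `COc1cc(/C=C2\CN(C)C/C(=C\c3ccccc3F)C2=O)cc(OC)c1` gives 5450 nM, compound 2 `COc1cc(/C=C2\CN(C)C/C(=C\c3ccc(Cl)cc3)C2=O)cc(OC)c1` gives 11200 nM, and compound 3 `COc1cc(/C=C2\CN(C)C/C(=C\c3ccc(Cl)c(Cl)c3)C2=O)cc(OC)c1` gives 6900 nM. Compound 3 cannot be separated from either of the others, as the record shows a 1.3-fold higher number from compound 1 to compound 3 (0.10 log units; within the scatter) and a 1.6-fold lower number from compound 2 to compound 3 (0.21 log units; within the scatter).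

The next case is compound 4 `COc1cc(/C=C2\CN(C)C/C(=C\c3cccc([N+](=O)[O-])c3)C2=O)cc(OC)c1`, and the change is 3-nitrophenyl in place of 3,4-dichlorophenyl on a double-bonded chain carbon bound to a double-bonded ring carbon. In words, it places 3-nitrophenyl in place of 3,4-dichlorophenyl on a double-bonded chain carbon bound to a double-bonded ring carbon. Within the data shown here, all three measured steps bear on this, since each alters the phenyl group at that place, although none of the measured compounds carries a nitro group. Because a 2.1-fold higher number from compound 1 to compound 2 (0.31 log units; beyond the scatter) is the largest exchange seen there, no step beyond the scatter is expected in this assay, and no direction is favoured. The expected outcome is a 1.0-fold higher number from compound 3 to compound 4 (0.01 log units; within the scatter). Compound 4 is estimated at 7000 nM, with an expected range of 3000 nM to 16000 nM.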

Compound 4, half-maximal inhibitory concentration: 2560 nM
Beside the measured number, compound 4's estimate is 2.7-fold (0.44 log units) above it; the measured number lies below the stated range.
By their numbers in this assay, from the lowest: compound 4; then compounds 1, 3 and 2 (each within the scatter of the next, the first and the last beyond it).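

In this assay, among these compounds, the earlier halogen-bearing phenyl groups at this place gave only one step beyond the scatter, and it ran upward, whereas 3-nitrophenyl brings a lower number against all three: a 2.7-fold lower number from compound 3 to compound 4 (0.43 log units; beyond the scatter) and a 2.1-fold lower number from compound 1 to compound 4 (0.33 log units; beyond the scatter) and also a 4.4-fold lower number from compound 2 to compound 4 (0.64 log units; beyond the scatter) in this series. Among the compounds shown here, compound 4 is therefore the strongest of the four, and it is the first here whose group on this carbon carries no halogen and has hydrogen-bond acceptors, though a single compound cannot tie the lower number to either feature. Nothing at hand gives a cause for the shift.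

The compounds shown leave open whether the lower number belongs to the nitro group as such, or whether a 3-cyanophenyl or 3-aminophenyl group on the same carbon would give it too. They also leave open whether a 4-nitrophenyl group would match 3-nitrophenyl.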